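The source may report more compounds than this note shows. Statements on the series, on what has been measured and on what is new or still open speak of the compounds shown alone.

Measured in a functional assay on HeLa cells (Homo sapiens) for cytotoxicity, read by MTT assay, with a stated time of 72 h; a lower number here means a stronger inhibitor, a higher number a weaker inhibitor:
- Compound 1 `C[C@@H](c1ccccc1)n1sc2ccccc2c1=O`: 30900 nM
- Compound 2 `O=c1c2ccccc2sn1Cc1ccccc1`: 20600 nM

Compound 2 and compound 1 lie within the scatter of each other, so compound 2 does not stand apart on these numbers. Compound 3 `C[C@H](c1ccccc1)n1sc2ccccc2c1=O` is the next case. It differs from compound 2 by methyl in place of hydrogen on a saturated chain carbon bound to an aromatic carbon and an aromatic nitrogen. Compound 3 has the opposite configuration at that carbon from compound 1. Going by the values given here, only one measured step bears on this change, a 1.5-fold lower number from compound 1 to compound 2 (0.18 log units; within the scatter), and it runs in the reverse direction from the other configuration. Among the compounds with values here, no measurement yet compares the two configurations, so the expectation is uncertain. The expected change is a 1.3-fold higher number from compound 2 to compound 3 (0.12 log units; within the scatter), which would be no shift beyond the scatter. For compound 3 the estimated value is 27000 nM, with an expected range from 13000 nM to 55000 nM.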

Compound 3, half-maximal inhibitory concentration: 43700 nM
For compound 3 the middle estimate is 1.6-fold (0.21 log units) below the measured one, within the range that was stated.
By their numbers in this assay, from the lowest: compounds 2, 1 and 3 (each within the scatter of the next, the first and the last beyond it).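

In this assay, methyl in place of hydrogen on this saturated chain carbon now gives a step beyond the scatter, though a modest one: a 2.1-fold higher number from compound 2 to compound 3 (0.33 log units; beyond the scatter). The same change in the other configuration, seen in compound 1, stayed within the scatter of compound 2, so the effect of adding methyl here is only just detectable and appears in one configuration alone. The direct comparison of configuration gives a 1.4-fold higher number from compound 1 to compound 3 (0.15 log units; within the scatter), so the two methyl compounds are not separated on these numbers, and that comparison isolates a single variable: the fact that compounds 1 and 3 differ only in the configuration as drawn.

The compounds shown leave open whether an ethyl group or a carboxylic acid on this carbon would move the number further. They also leave open whether an amine on the same carbon would do so in either configuration.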